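Swapping 2,4-dimethoxyphenyl for pyridin-2-yl on the carbonyl carbon

The source may hold more compounds than are shown below. What is called first, only, known or untested is meant among the compounds shown, and "the series" means these compounds.

Compound 1 (`COc1ccc(-c2cc3ccccc3nc2C=O)cc1`) gives no number in a functional assay on SK-BR-3 cells (Homo sapiens) for antiproliferative activity, read by XTT assay, with a stated time of 72 h (on this read-out lower numbers stand for stronger inhibition and higher numbers for weaker inhibition), only the limit > 10000 nM.

Two relatives of compound 1 do give numbers in this assay. Compound 2 (`COc1ccc(-c2cc3ccccc3nc2/C=C/C(=O)c2ccc(O)cc2)cc1`) gives 3880 nM, and compound 3 (`COc1ccc(-c2cc3ccccc3nc2/C=C/C(=O)c2ccc(OC)cc2OC)cc1`) gives 2260 nM. These two numbers lie within the scatter of each other, so compound 3 stands level with compound 2 and no order can be drawn between them.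

The next structure is compound 4 (`COc1ccc(-c2cc3ccccc3nc2/C=C/C(=O)c2ccccn2)cc1`), which has not yet been measured. It differs from compound 3 by one exchange on the carbonyl carbon, pyridin-2-yl in place of 2,4-dimethoxyphenyl on a carbonyl carbon.

Within the data shown here, only one measured step bears on this exchange. It is a 1.7-fold lower number from compound 2 to compound 3 (0.23 log units; within the scatter), with 2,4-dimethoxyphenyl in place of 4-hydroxyphenyl on the same carbonyl carbon. That step is a weak guide, as neither of its compounds carries a ring with a hetero atom in this place. Among the measured compounds shown here, with a 1.7-fold lower number from compound 2 to compound 3 (0.23 log units; within the scatter) as the only evidence, no step beyond the scatter is expected in either direction, although the uncertainty is wide. The expected step is a 1.5-fold higher number from compound 3 to compound 4 (0.19 log units; within the scatter). For compound 4 the estimated value is 3500 nM, with an expected range from 1200 nM to 10000 nM.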

Compound 4, half-maximal inhibitory concentration: 370 nM
The estimate for compound 4 lay 9.5-fold (0.98 log units) above the measured number; the whole stated range lies above it.
By their numbers in this assay, from the lowest: compound 4; then compounds 3 and 2 (each within the scatter of the next). At a limit, above all of these: compound 1.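

Pyridin-2-yl in place of 2,4-dimethoxyphenyl on the carbonyl carbon brings a 6.1-fold lower number from compound 3 to compound 4 (0.79 log units; beyond the scatter) in this assay, and pyridin-2-yl in place of 4-hydroxyphenyl brings a 10-fold lower number from compound 2 to compound 4 (1.02 log units; beyond the scatter). Among these compounds, the two carbon-only rings had stood within the scatter of each other, so the earlier compounds gave no sign that this position could move the number, whereas compound 4 shows that it can, and that a ring with a hetero atom on the carbonyl carbon is compatible with a clearly lower number. Nothing measured here accounts for this gain.

The exchange alters several things at once, since pyridin-2-yl brings a ring nitrogen, drops the substituents of the carbon-only rings and has fewer heavy atoms, and the compounds shown do not separate these changes. Unsubstituted phenyl would show whether losing the substituents alone gives the lower number, while pyridin-3-yl and pyridin-4-yl would show whether the place of the ring nitrogen matters, and substituents on the pyridine ring remain equally open.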